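The compounds below may be only part of what the source reports. "The series", "measured", "known", "first", "only" and "open" are said of these compounds alone.

Measured compounds in a functional assay on U-87MG ATCC cells (Homo sapiens) for cytotoxicity, read by MTT assay, with a stated time of 72 h; a higher number here means a weaker inhibitor, a lower number a stronger inhibitor:
- compound 1, `CN(C)CCn1cnnc1-c1cc(Oc2ccc(NC(=O)N/N=C/c3ccc(F)cc3)cc2F)ccn1`: 2310 nM
- compound 2, `CN(C)CCn1cnnc1-c1cc(Oc2ccc(NC(=O)N/N=C/c3cccc(Br)c3)cc2F)ccn1`: 830 nM
- compound 3, `CN(C)CCn1cnnc1-c1cc(Oc2ccc(NC(=O)N/N=C/c3ccc(Cl)cc3)cc2F)ccn1`: 1370 nM

Compound 3 gives the second-highest of the three numbers in this assay. Its nearest neighbour is compound 2 (a 1.7-fold higher number from compound 2 to compound 3 (0.22 log units; within the scatter)) and its furthest is compound 1 (a 1.7-fold lower number from compound 1 to compound 3 (0.23 log units; within the scatter)); both gaps lie within the scatter, so the three halogenated phenyl variants are not separated on these data.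

Compound 4, `CN(C)CCn1cnnc1-c1cc(Oc2ccc(NC(=O)N/N=C/c3ccc(F)cc3Cl)cc2F)ccn1`, carries the change (2-chloro-4-fluorophenyl in place of 4-chlorophenyl on a carbon with a double bond to nitrogen). It keeps a halogen at the position already present in compound 3 and adds a second one. Going by the values given here, two measured steps bear on this. The exchange of one halogen for another, a 1.7-fold lower number from compound 1 to compound 3 (0.23 log units; within the scatter), lay within the scatter. Moving and changing the halogen, a 2.8-fold lower number from compound 1 to compound 2 (0.44 log units; beyond the scatter), gave a modest step beyond the scatter. Among the compounds with values here, no measured pair shows the effect of a second halogen on the same ring. A small step, if any, is therefore expected; the estimated step of a 1.1-fold lower number from compound 3 to compound 4 (0.06 log units; within the scatter) is taken as lying within the scatter. Compound 4 is expected to give 1200 nM in this assay, with a range of 500 nM to 2800 nM.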

Compound 4, half-maximal inhibitory concentration: 1210 nM
Beside the measured number, compound 4's estimate is 1.0-fold (0.00 log units) below it; low and high end bracket the measured number.
By their numbers in this assay, from the lowest: compounds 2, 4, 3 and 1 (each within the scatter of the next, the first and the last beyond it).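

Going by these compounds alone, the first measured pair with a second halogen on one ring comes with the extra chloro of the 2-chloro-4-fluorophenyl group, and in this assay this step, a 1.9-fold lower number from compound 1 to compound 4 (0.28 log units; within the scatter), stays within the scatter. The 2-chloro-4-fluorophenyl group, with 8 heavy atoms, also cannot be separated from 4-chlorophenyl, a 1.1-fold lower number from compound 3 to compound 4 (0.05 log units; within the scatter), or from 3-bromophenyl, a 1.5-fold higher number from compound 2 to compound 4 (0.16 log units; within the scatter), when placed on a carbon with a double bond to nitrogen. No supporting measurement is available to explain these small steps.

Every group shown at this place is a halogenated phenyl, so it remains open whether an amine or a carboxylic acid on that ring would give a step beyond the scatter. From the compounds shown here alone, the effect of changes to the shared core or to the dimethylaminoethyl chain also remains open.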